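This account rests on a few compounds, and the source may have more. Where it says the series, first, only, none or still open, it means among the compounds named here.

Measured so far in an ADME assay for permeability, using PAMPA, at pH 5.5; a lower number here means that the compound crosses the layer more slowly, a higher number that the compound crosses the layer faster:
- compound 1 `CN(C[C@H]1Cc2c(cccc2N2CCN(Cc3ccccn3)CC2)CN1)[C@H]1CCCc2cccnc21`: 82 nm/s
- compound 2 `CN(C[C@H]1Cc2c(cccc2N2CCN(c3ncccn3)CC2)CN1)[C@H]1CCCc2cccnc21`: 360 nm/s

Among the measured compounds shown here, only two numbers exist in this assay, and compound 2 holds the higher one, at 360 nm/s. For the measured compounds named here, the single measured step is a 4.4-fold higher number from compound 1 to compound 2 (0.64 log units; beyond the scatter). It came with pyrimidin-2-yl in place of (pyridin-2-yl)methyl on an amine nitrogen in a ring.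

Compound 3 `CN(C[C@H]1Cc2c(cccc2N2CCN(c3ccccn3)CC2)CN1)[C@H]1CCCc2cccnc21` has not been measured yet. It keeps the shared core and changes one group at that same ring nitrogen: pyridin-2-yl in place of pyrimidin-2-yl on an amine nitrogen in a ring.

Going by the values given here, no measured step makes exactly this swap, so the evidence is indirect. Among the compounds with values here, the one step available does bear on it, since it involves the same place on the molecule. The group in compound 1, (pyridin-2-yl)methyl, also contains pyridin-2-yl, and compound 1 gives 82 nm/s. That points to a landing spot between the two measured values, probably closer to compound 2, which shares the directly attached ring type.

The expected step is a 1.8-fold lower number from compound 2 to compound 3 (0.26 log units; within the scatter), a lower number but a smaller move than the measured one. For compound 3 the estimated value is 200 nm/s, with an expected range of 90 nm/s to 450 nm/s.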

Compound 3, apparent permeability: 129 nm/s
For compound 3 the middle estimate is 1.6-fold (0.19 log units) above the measured one, and the stated range covers the measured number.
By their numbers in this assay, from the lowest: compounds 1 and 3 (each within the scatter of the next); then compound 2.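

In this assay, the change of ring on the amine nitrogen alone gives a 2.8-fold lower number from compound 2 to compound 3 (0.45 log units; beyond the scatter) with the ring still attached directly, and here pyridin-2-yl, with 1 hetero atom, replaces pyrimidin-2-yl, with 2 hetero atoms. The earlier step changed both the ring and its link to the nitrogen, so it could not separate the two; this step shows that the identity of the ring counts on its own. Removing the methyl link from the pyridine-bearing group gives a 1.6-fold higher number from compound 1 to compound 3 (0.20 log units; within the scatter) and leaves the two compounds indistinguishable, so among these three compounds the higher number stands only with pyrimidin-2-yl, and nothing available explains this difference.

A plain phenyl ring, with no ring nitrogen, or a pyrazin-2-yl ring, with its two nitrogens arranged differently, would test whether the count of ring nitrogens or their arrangement tracks the number. A longer chain such as 2-(pyridin-2-yl)ethyl, or a (pyrimidin-2-yl)methyl group, would show whether a link on the nitrogen matters once the ring is pyrimidin-2-yl.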